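Butylamino to butylsulfinyl on the shared core

The compounds below may be only part of what the source reports. "The series", "measured", "known", "first", "only" and "open" are said of these compounds alone.

Measured so far:
compound 1 `CCCCNc1nc(N)c2nc(O)n(Cc3ccccc3)c2n1` gives 1 uM
compound 2 `Nc1ncnc2c1nc(O)n2-c1ccccc1` gives > 10 uM, a limit
compound 3 `Cc1nc2c(N)ncnc2n1Cc1ccccc1` gives > 10 uM, a limit

Among the measured compounds shown here, in a functional assay (spleen, spleen) for activation, with Mus musculus as the target (a lower number here means that less compound is needed, a higher number that more compound is needed for the effect), compound 1 gives 1 uM, the only actual number among the three results. Compound 2 reaches only a limit of the assay at > 10 uM. Compound 3 likewise stops at a limit, > 10 uM. For the measured compounds named here, compound 1 therefore stands apart from the limit of > 10 uM in this assay, at which 2 of the 3 values shown sit, and it is the one compound here with a measured minimum effective concentration.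

Going by the values given here, no two measured compounds differ in a single place, so no measured step exists to guide the next change. Compound 4 `CCCC[S+]([O-])c1nc(N)c2nc(O)n(Cc3ccccc3)c2n1` has not been measured. It differs from compound 1 as follows: a group of 6 heavy atoms (4 carbon, 1 oxygen, 1 sulfur; no ring) in place of a group of 5 heavy atoms (4 carbon, 1 nitrogen; no ring), on an aromatic carbon. The butylamino group leaves and a butylsulfinyl-type group of 6 heavy atoms enters at the same aromatic carbon.

With no measured step of this kind in the series, the expectation rests on compound 1 alone. A step from compound 1 to compound 4 of a 3.0-fold higher number from compound 1 to compound 4 (0.48 log units; beyond the scatter) is expected in this assay, toward more compound being needed, somewhat beyond the scatter. Compound 4 is estimated at 3 uM, with a range from 0.7 uM to 15 uM.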

Compound 4, minimum effective concentration: 0.01 uM
Beside the measured number, compound 4's estimate is 300-fold (2.48 log units) above it; the whole stated range lies above it.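

In this assay, the aromatic carbon between two ring nitrogen atoms emerges as a highly sensitive position: replacing butylamino with the butylsulfinyl-type group gives a 100-fold lower number from compound 1 to compound 4 (2.00 log units; beyond the scatter). The entering group has 0 hydrogen-bond donors where butylamino has 1 hydrogen-bond donor, so a donor at this carbon is not required for the effect in this compound pair. Among the compounds shown here, this is also the first measured change in a single place, and it shows that the read-out can move widely with the rest of the core of compound 1 held fixed.

This one step cannot separate the contribution of the sulfur from that of its oxygen, so butylthio, butylsulfonyl and a longer chain on the sulfur remain the open comparisons at this carbon. Compound 2 and compound 3 are both limits of the assay and supply no number for reading changes elsewhere on the core: the limit of > 10 uM in this assay, at which 2 of the 4 values shown sit.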